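This account rests on a few compounds, and the source may have more. Where it says the series, first, only, none or still open, it means among the compounds named here.

Compound 1 `C=C1C=CC(=O)[C@@H]2[C@H](Cc3ccc(F)c(F)c3)CC[C@H]12`: 478 nM
Compound 2 `C=C1C=CC(=O)[C@@H]2[C@H](Cc3ccc(OC)c(F)c3)CC[C@H]12`: 2.77 nM

In a functional assay on KB cells (Homo sapiens) for antiproliferative activity, with a stated time of 72 h (on this read-out lower numbers stand for stronger inhibition and higher numbers for weaker inhibition), compound 2 gives the lower of the two numbers, at 2.77 nM. The next analogue, compound 3 `C=C1C=CC(=O)[C@@H]2[C@H](Cc3ccc(O)c(F)c3)CC[C@H]12`, differs from it by hydrogen in place of methyl on an oxygen on an aromatic ring, or methoxy to hydroxy. Among the measured compounds shown here, only one measured step bears on this change, a 170-fold lower number from compound 1 to compound 2 (2.24 log units; beyond the scatter), with methoxy in place of fluoro on an aromatic carbon. For the measured compounds named here, that large step shows that the read-out can respond strongly to the group changed there, but no measured compound carries hydroxy, so the direction remains a judgement. A move to a higher number in this assay is expected, beyond the scatter but smaller than the measured step. The expected change is a 9.0-fold higher number from compound 2 to compound 3 (0.96 log units; beyond the scatter). The estimate for compound 3 is 25 nM, with an expected range of 4 nM to 150 nM.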

Compound 3, half-maximal inhibitory concentration: 156 nM
Compound 3: the middle estimate sits 6.2-fold (0.80 log units) below what was measured; measured number outside the range, above it.
By their numbers in this assay, from the lowest: compound 2; then compound 3; then compound 1.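

In this assay, the methyl on the oxygen proves to matter in its own right: removing it gives a 56-fold higher number from compound 2 to compound 3 (1.75 log units; beyond the scatter), so the oxygen alone does not preserve the low number of the methoxy compound. Hydroxy in place of fluoro gives only a 3.1-fold lower number from compound 1 to compound 3 (0.49 log units; beyond the scatter), a modest gain beside the large step produced by removing the methyl, so most of the advantage of methoxy over fluoro in this pair of changes depends on the methyl being present. Nothing available explains why this methyl has so large an effect on the read-out. The compounds shown leave open whether a longer chain on the oxygen, such as ethoxy, keeps or loses the low number. They also leave open how an amine would compare with hydroxy and methoxy on that aromatic carbon.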